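Diaryl ether thioureas: cytotoxicity notes toward compound 4

A few compounds are considered here, and "the series" means these few. Any claim that something is new, unique, unknown or untested is made for them only; others in the source may bear on it.

Measured so far:
compound 1 `CNC(=O)c1cc(Oc2cccc(NC(=S)Nc3ccc(Cl)cc3Cl)c2)ccn1`: > 100000 nM, a limit of the assay
compound 2 `CCNC(=O)c1cc(Oc2cccc(NC(=S)Nc3ccc(F)c(F)c3)c2)ccn1`: > 100000 nM, a limit of the assay
compound 3 `O=C(NC1CCCCC1)c1cc(Oc2cccc(NC(=S)Nc3ccc(F)c(F)c3)c2)ccn1`: > 100000 nM, a limit of the assay

In a functional assay on MDA-MB-231 cells (Homo sapiens) for cytotoxicity, read by MTT assay, with a stated time of 48 h (on this read-out lower numbers stand for stronger inhibition and higher numbers for weaker inhibition), every value recorded for the three measured compounds is a limit and not a number. Compound 1 therefore stands only at the limit > 100000 nM in this assay, with no placing relative to the others possible. Among the measured compounds shown here, the one step between measured compounds that differ in a single place, a step that the two limits leave unreadable from compound 2 to compound 3, concerns the amide nitrogen of the core and is itself unreadable; it says nothing about the aryl group on the thiourea.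

Compound 4 `CNC(=O)c1cc(Oc2cccc(NC(=S)Nc3cccc(C(F)(F)F)c3)c2)ccn1` is obtained from compound 1 by 3-(trifluoromethyl)phenyl in place of 2,4-dichlorophenyl on an amide-type nitrogen. For the measured compounds named here, no measured step touches this position, so neither size nor direction of the change in this assay can be read from the data. Because (the limit of > 100000 nM in this assay, at which 3 of the 3 values shown sit), the expectation leans toward compound 4 also reaching the limit in this assay. Compound 4 is estimated at 100000 nM in this assay, with a range from 20000 nM to 300000 nM. The step this estimate implies, a number no higher from compound 1 to compound 4 (the limit leaves the size open), is expected to show no change beyond the scatter, with a real chance that only a limit is reported again.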

Compound 4, half-maximal inhibitory concentration: > 100000 nM
Compound 4 ended at the assay's limit; the forecaster's own chance of this, stated with the estimate: 75%; the middle value sits exactly at the limit.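

In this assay compound 4 gives > 100000 nM, a limit of the assay and not a number. With compound 1 also at a limit, the step between compound 1 and compound 4 cannot be read. The compounds shown leave open whether any change on the thiourea aryl group or the amide nitrogen gives a measurable value: the limit of > 100000 nM in this assay, at which 4 of the 4 values shown sit.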